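The source may report more compounds than this note shows. Statements on the series, on what has been measured and on what is new or still open speak of the compounds shown alone.

Working notes on the series.

Among the measured compounds shown here, compound 3 `CCCCCCCCCCc1cn(C[C@H](O)[C@H]2OC(=O)C(OCc3ccccc3)=C2OCc2ccccc2)nn1` is the one member of the set with a number rather than a limit: in a functional assay on SW-620 cells (Homo sapiens) for antiproliferative activity, read by MTT assay, with a stated time of 72 h (a lower number here means a stronger inhibitor, a higher number a weaker inhibitor), compound 3 gives 45200 nM. Compound 1 `O=C1O/C(=C\Cn2cc(-c3ccc(Br)cc3)nn2)C(OCc2ccccc2)=C1OCc1ccccc1` sits at the limit of this assay with > 100000 nM. Compound 2 `Cc1ccc(-c2cn(C/C=C3\OC(=O)C(OCc4ccccc4)=C3OCc3ccccc3)nn2)cc1` likewise reaches only the limit of this assay with > 100000 nM. For the measured compounds named here, the one measured step, a step that the two limits leave unreadable from compound 1 to compound 2, is therefore unreadable, and the only evidence on the measured steps is the limit of > 100000 nM in this assay, at which 2 of the 3 values shown sit.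

Compound 4 `COc1ccc(-c2cn(C[C@H](O)[C@H]3OC(=O)C(OCc4ccccc4)=C3OCc3ccccc3)nn2)cc1` differs from compound 3 in one place: 4-methoxyphenyl in place of decyl on an aromatic carbon. The change puts a six-membered aromatic ring on the five-membered aromatic ring with 3 nitrogen, where compounds 1 and 2 also carry an aromatic ring on their own cores, and both of those compounds reach only the limit. Going by the values given here, no measured step bears directly on the exchange of decyl for 4-methoxyphenyl on this core, so no size can be read from the data. Taking the two limits for compounds 1 and 2 as the nearest guide, a weakening in this assay is expected for compound 4, with a fair chance that only a limit is reported, the step expected being a 2.4-fold higher number from compound 3 to compound 4 (0.39 log units; beyond the scatter). Compound 4 is estimated at 110000 nM, within 30000 nM to 400000 nM.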

Compound 4, half-maximal inhibitory concentration: 58200 nM
For compound 4 the middle estimate is 1.9-fold (0.28 log units) above the measured one; the measured number falls inside the stated range.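

In this assay, the exchange of decyl for 4-methoxyphenyl on the aromatic carbon of the five-membered aromatic ring with 3 nitrogen is a 1.3-fold higher number from compound 3 to compound 4 (0.11 log units; within the scatter), so this position on the shared core shows no readable preference between the two groups. The entering group brings a six-membered aromatic ring and a hydrogen-bond acceptor, which the decyl chain lacks, and the number still stays within the scatter. Among the compounds shown here, an aromatic ring at this place on this core therefore gives a measured number and not a limit of the assay, which the earlier compounds could not show.

Compound 4 differs from compounds 1 and 2 in more than one place, and the step between those two cannot be read, so the part played by the link between the core and the five-membered ring stays unsettled: the limit of > 100000 nM in this assay, at which 2 of the 4 values shown sit. Also open, as far as these compounds go, is whether a shorter alkyl chain, an amine or a carboxylic acid at this position, or a free hydroxyl in place of a benzyl ether on the core, would move the number beyond the scatter.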